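The source may report more compounds than this note shows. Statements on the series, on what has been measured and on what is new or still open speak of the compounds shown alone.

Compound 1 `Clc1ccc(-c2cc(-c3ccsc3)nc(-c3ccco3)c2)o1` gives > 50000 nM in a functional assay on HCT-15 cells (Homo sapiens) for cytotoxicity, in the presence of a further agent that is not named here (a higher number here means a weaker inhibitor, a lower number a stronger inhibitor), a limit of the assay rather than a number.
Compound 2 `Clc1ccc(-c2cc(-c3ccco3)nc(-c3cccs3)c2)o1` gives > 50000 nM in this assay, again only a limit.
Compound 3 `Clc1ccc(-c2cc(-c3ccoc3)cc(-c3ccsc3)n2)cc1` gives > 100000 nM in this assay, also a limit.

Compound 2 therefore stands at a limit, and the two other values shown are limits as well: two of the three sit at the limit of > 50000 nM in this assay, at which 2 of the 3 values shown sit, and one at the limit of > 100000 nM in this assay, at which 1 of the 3 values shown sits. Among the compounds with values here, the only single-point step among the measured compounds, a step that the two limits leave unreadable from compound 1 to compound 2, runs between two limits and its size cannot be read. Compound 4 `Cc1ccc(-c2cc(-c3ccc(Cl)o3)cc(-c3cccs3)n2)cc1` differs from compound 2 by 4-methylphenyl in place of furan-2-yl on an aromatic carbon. Within the data shown here, none of the measured steps bears on this kind of change, and the one step that is known is itself unreadable, so the account offers no measured basis for a shift in either direction. The expected step that the limit leaves unreadable from compound 2 to compound 4 is therefore set at none beyond the scatter. Compound 4 is expected to give about 60000 nM in this assay, with a range from 15000 nM to 200000 nM, and most likely only a limit will be reported.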

Compound 4, half-maximal inhibitory concentration: 9890 nM
Compound 4: the middle estimate sits 6.1-fold (0.78 log units) above what was measured, outside the stated range (below it).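

Putting 4-methylphenyl in place of furan-2-yl on the aromatic carbon next to the ring nitrogen gives an at least 5.0-fold lower number from compound 2 to compound 4 (0.70 log units; beyond the scatter) in this assay, the first step shown here that can be read. The only earlier step cannot be read, so this is the first sign among the compounds shown that a change in one place moves the result. The step gives only a lower bound on the size of the change because compound 2 stands at a limit and not at a number: the limit of > 50000 nM in this assay, at which 2 of the 4 values shown sit.

The compounds shown do not separate the effect of the six-membered ring itself from that of its methyl group. From the compounds shown here alone, how a methoxy group or an amine on that ring would read remains open, as does whether the step carries over to compound 1 with its thiophen-3-yl group.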